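The source may hold more compounds than are shown below. What is called first, only, known or untested is meant among the compounds shown, and "the series" means these compounds.

For the measured compounds named here, in a functional assay on NCI-H1975 cells (Homo sapiens) for cytotoxicity, read by MTT assay, with a stated time of 72 h (a lower number here means a stronger inhibitor, a higher number a weaker inhibitor), compound 1 `O=C(N/N=C/c1ccc(Br)cc1)N1CCc2ncnc(Nc3cccc(Br)c3)c2C1` gives 51000 nM, the only exact number available so far. Compound 2 `O=C(N/N=C/c1ccco1)N1CCc2ncnc(Nc3cccc(Br)c3)c2C1` reports > 200000 nM, which is a limit of the assay. Going by the values given here, the single measured step, furan-2-yl in place of 4-bromophenyl, is an at least 3.9-fold higher number from compound 1 to compound 2 (0.59 log units; beyond the scatter). It bears only indirectly, since it lies at a different place from the change considered here. Compound 3 `O=C(N/N=C/c1ccc(Br)cc1)N1CCc2ncnc(Nc3cccc(C(F)(F)F)c3)c2C1` differs by trifluoromethyl in place of bromo on an aromatic carbon, with trifluoromethyl in place of bromo on an aromatic carbon. Among the compounds with values here, no measured step covers this place, so no change beyond the scatter is expected. The expected step is a 1.0-fold lower number from compound 1 to compound 3 (0.01 log units; within the scatter). For compound 3 the estimated value is 50000 nM, with an expected range of 20000 nM to 125000 nM.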

Compound 3, half-maximal inhibitory concentration: 61400 nM
For compound 3 the middle estimate is 1.2-fold (0.09 log units) below the measured one; low and high end bracket the measured number.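

In this assay, trifluoromethyl in place of bromo on the aromatic carbon gives a 1.2-fold higher number from compound 1 to compound 3 (0.08 log units; within the scatter). This first reading at this position does not tell the two groups apart, whereas the step from 4-bromophenyl to furan-2-yl at the other place lies beyond the scatter. Nothing at hand gives a reason for this result. Going by these compounds, whether an amine or a carboxylic acid on this aromatic carbon would leave the number unchanged stays open. So does whether the same exchange would read alike with furan-2-yl at the other place.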